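Methyl on the piperazine nitrogen in two related quinazolines

The source may hold more compounds than are shown below. What is called first, only, known or untested is meant among the compounds shown, and "the series" means these compounds.

Of the compounds shown here, three have been tested in a functional assay on DU-145 cells (Homo sapiens) for antiproliferative activity, read by MTT assay; on this read-out lower numbers stand for stronger inhibition and higher numbers for weaker inhibition. Compound 1 `c1ccc2c(c1)ccn2-c1nc(N2CCNCC2)nc2ccccc12` gives 12.5 ug/mL. Compound 2 `CN1CCN(c2nc(-n3ccc4ccccc43)c3ccccc3n2)CC1` differs from compound 1 by methyl in place of hydrogen on an amine nitrogen in a ring, and in this assay compound 2 gives 20.8 ug/mL. The step from compound 1 to compound 2 is a 1.7-fold higher number from compound 1 to compound 2 (0.22 log units; within the scatter), so the two numbers cannot be told apart with confidence.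

Compound 3 `Cn1cc(-c2nc(N3CCNCC3)nc3ccccc23)c2ccccc21` carries a different core from compound 1; the difference between the two cores is not broken down here. In this assay compound 3 gives 50 ug/mL, which stands as the highest of the three numbers, beyond the scatter relative to both compound 1 and compound 2.

Compound 4 `CN1CCN(c2nc(-c3cn(C)c4ccccc34)c3ccccc3n2)CC1` has not yet been measured. Going by the values given here, it differs from compound 3 by methyl in place of hydrogen on an amine nitrogen in a ring, the same change, at the same kind of place, as the one made from compound 1 to compound 2. Because that earlier step was a 1.7-fold higher number from compound 1 to compound 2 (0.22 log units; within the scatter), the expectation for the step from compound 3 to compound 4 is a comparable small shift, estimated as a 1.5-fold higher number from compound 3 to compound 4 (0.18 log units; within the scatter). On this basis compound 4 is expected to give about 75 ug/mL in this assay. The estimate for compound 4 is bounded from 40 ug/mL to 150 ug/mL, a range that reflects both the scatter of single measurements and the fact that the change has been seen only once so far.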

Compound 4, half-maximal inhibitory concentration: 50 ug/mL
For compound 4 the middle estimate is 1.5-fold (0.18 log units) above the measured one; low and high end bracket the measured number.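

In this assay, methyl in place of hydrogen on the ring amine nitrogen of the piperazine gives no change at the digits printed from compound 3 to compound 4 (within the scatter). Set beside the earlier step, the change carries from one core to the other without a readable difference between the two cores: the same change on two cores in this assay, a 1.7-fold higher number (0.22 log units; within the scatter) from compound 1 to compound 2 and no change at the digits printed (within the scatter) from compound 3 to compound 4, 1.7-fold (0.22 log units) apart, within the scatter of two such steps. This shows that, on these two cores and in this one assay, going from piperazin-1-yl to 4-methylpiperazin-1-yl does not move the number beyond the normal spread of repeat measurements, but it does not show that the change is without any effect, since a small shift could hide within that spread, and two pairs of compounds say nothing about how a third core would respond.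

The compounds shown hold only hydrogen or methyl on this nitrogen, so it remains open whether a longer chain such as propyl, or a chain ending in a carboxylic acid, would leave the number equally unmoved. Going by these compounds, it also remains open whether such a group would behave the same way on both cores, which only matched pairs on each core could answer.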